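The source may report more compounds than this note shows. Statements on the series, on what has been measured and on what is new or still open speak of the compounds shown alone.

Within the data shown here, compound 2 `CC#C[C@H](CC(=O)O)c1ccc(OC[C@@H]2COc3ccc(Cl)cc3O2)cc1` is one of two compounds measured in a functional assay on HEK293 cells for agonist activity at Free fatty acid receptor 1 (Homo sapiens), read by fluorescence and calcium flux, with a stated time of 10 min; on this read-out higher numbers stand for larger maximal responses and lower numbers for smaller maximal responses. Compound 1 `CC#C[C@H](CC(=O)O)c1ccc(OC[C@H]2COc3ccc(Cl)cc3O2)cc1` gives 47% in this assay, and compound 2 gives 41%, so the two values sit within the scatter of each other; the step of a number 6 percentage points lower from compound 1 to compound 2 (within the scatter) rests on (the fact that compounds 1 and 2 differ only in the configuration as drawn). Compound 3 `CC#C[C@@H](CC(=O)O)c1ccc(OC[C@@H]2COc3ccc(Cl)cc3O2)cc1` is again a change of configuration only: the two compounds have the same atoms and bonds and differ only in configuration as drawn: 1 of 2 stereo elements differ; a stereocentre at a saturated chain carbon is drawn R in compound 2 and S in compound 3. Among the measured compounds shown here, the one measured step concerns the stereocentre at the saturated ring carbon, not the one at the chain carbon, so it bears on this change only loosely, and it was small. The expectation for compound 3 is therefore uncertain and carries a broad range. Compound 3 is estimated to give 30%, between 5% and 60%. The expected step of a number 11 percentage points lower from compound 2 to compound 3 (beyond the scatter) leans toward a smaller response, but it may well fall within the scatter.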

Compound 3, largest response reached (Emax), in percent of the reference or control that the assay uses: 65%
Compound 3: middle estimate off by 35 percentage points, on the low side; measured number above the stated range.
By their numbers in this assay, from the lowest: compounds 2 and 1 (each within the scatter of the next); then compound 3.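

In this assay, the configuration at the saturated chain carbon matters in a way the ring carbon had not shown: inverting the chain carbon gives a number 24 percentage points higher from compound 2 to compound 3 (beyond the scatter), whereas inverting the ring carbon gave a number 6 percentage points lower from compound 1 to compound 2 (within the scatter). The mirror-image pair also separates, with a number 18 percentage points higher from compound 1 to compound 3 (beyond the scatter), so the maximal response depends on the handedness of the whole molecule and not only on its atoms and bonds. Since no group enters or leaves, the step from compound 2 to compound 3 can be attributed only to the arrangement in space: the fact that compounds 2 and 3 differ only in the configuration as drawn

On these data alone, it remains open how the chain carbon behaves when the ring carbon is drawn S, so the two stereocentres cannot yet be judged independently. As far as these compounds go, it is also open whether the preference for the S chain carbon would persist with an amide in place of the carboxylic acid.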